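The compounds below may be only part of what the source reports. "The series", "measured", "known", "first", "only" and "open" are said of these compounds alone.

Measured compounds in a functional assay on SNB-19 cells (Homo sapiens) for inhibition, read by sulforhodamine B assay, with a stated time of 48 h, tested at 10 uM; on this read-out higher numbers stand for more inhibition at the one concentration tested (going by the name of the read-out) and lower numbers for less inhibition:
- compound 1, `Brc1cn2ccnc2c(-c2ccc3ncn(C4CCCCC4)c3c2)n1`, gives 8.09%
- compound 2, `c1ccc(-c2cn3ccnc3c(-c3ccc4ncn(C5CCCCC5)c4c3)n2)cc1`, gives 22.9%
- compound 3, `COc1ccc(-c2cn3ccnc3c(-c3ccc4ncn(C5CCCCC5)c4c3)n2)cc1`, gives 68.4%

Compound 3 stands highest of the three; its nearest neighbour is compound 2, and the step from compound 2 to compound 3 is a number 45.5 percentage points higher from compound 2 to compound 3 (beyond the scatter), while the step from compound 1 to compound 3 is a number 60.3 percentage points higher from compound 1 to compound 3 (beyond the scatter). The smaller step of the series, a number 14.8 percentage points higher from compound 1 to compound 2 (beyond the scatter), shows that the phenyl alone adds little compared with what the methoxy on that phenyl adds.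

Compound 4, `O=Cc1ccc(-c2cn3ccnc3c(-c3ccc4ncn(C5CCCCC5)c4c3)n2)cc1`, differs from compound 3 by formyl in place of methoxy on an aromatic carbon. For the measured compounds named here, no measured step exchanges one substituent on that phenyl for another; only the step from compound 2 to compound 3 touches the same aromatic carbon, and it was large. Whether a formyl there keeps what the methoxy gave is not shown by the data. The expectation is therefore a value somewhere between the unsubstituted phenyl of compound 2 and compound 3, with a step of a number 23.4 percentage points lower from compound 3 to compound 4 (beyond the scatter) expected, most likely downward. Compound 4 is estimated at 45%, with a range of 15% to 75%.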

Compound 4, a percentage reported as inhibition, at one concentration (the size of the read-out at that concentration, not a potency): 14.4%
Compound 4: middle estimate off by 30.6 percentage points, on the high side, and the stated range ends above it.
By their numbers in this assay, from the lowest: compounds 1, 4 and 2 (each within the scatter of the next, the first and the last beyond it); then compound 3.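

In this assay the step of a number 54 percentage points lower from compound 3 to compound 4 (beyond the scatter) shows that the response at this aromatic carbon depends on which group sits there, even though methoxy and formyl match in the heavy-atom and hydrogen-bond acceptor counts. The steps of a number 8.5 percentage points lower from compound 2 to compound 4 (within the scatter) and a number 6.3 percentage points higher from compound 1 to compound 4 (within the scatter) both lie within the scatter, so compound 4 cannot be told apart from compound 2 or compound 1 on this read-out. Among the groups shown at this carbon, the high number belongs to the methoxy of compound 3 alone, and no measurement at hand accounts for the difference between methoxy and formyl.

Open, as far as these compounds go, is whether ethoxy, hydroxy or a dimethylamino group on that carbon would keep the number of compound 3 or match that of compound 4. With only two substituents on this phenyl, no trend across groups can be drawn yet.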